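This account rests on a few compounds, and the source may have more. Where it says the series, first, only, none or still open, it means among the compounds named here.

Compound 1 `Cn1c(/C=C2\SC(=O)N(CC(=O)Nc3cc(C(C)(C)C)on3)C2=O)nc2ccccc21` gives 33800 nM in a functional assay on MDA-MB-231 cells (Homo sapiens) for inhibition, read by MTT assay, with a stated time of 48 h; a lower number here means a stronger inhibitor, a higher number a weaker inhibitor.
Compound 2 `CC(C)n1c(/C=C2\SC(=O)N(CC(=O)Nc3cc(C(C)(C)C)on3)C2=O)nc2ccccc21` reaches only the limit of this assay, > 50000 nM.
Compound 3 `Cn1c(/C=C2\SC(=O)N(CC(=O)Nc3nc(-c4ccccc4)cs3)C2=O)nc2ccccc21` gives 29200 nM in this assay.

All three share one core and differ in two places. Compound 1 stands with the highest of the two plain numbers, but its nearest neighbour, compound 3, sits within the scatter of it: a 1.2-fold lower number from compound 1 to compound 3 (0.06 log units; within the scatter). As far as these compounds go, the other measured step, an at least 1.4-fold higher number from compound 1 to compound 2 (0.17 log units; that floor lies within the scatter), is a change on the aromatic nitrogen and ends at a limit, so its true size is unknown; its floor lies within the scatter as well (the limit of > 50000 nM in this assay, at which 1 of the 3 values shown sits).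

Compound 4 `Cn1c(/C=C2\SC(=O)N(CC(=O)N3CCCC3)C2=O)nc2ccccc21` carries the change (pyrrolidin-1-yl in place of (5-(tert-butyl)-1,2-oxazol-3-yl)amino on a carbonyl carbon). Within the data shown here, of the measured steps, only the one from compound 1 to compound 3 touches the same part of the molecule, and it was within the scatter. That step, however, swapped one aromatic ring for another on the amide-type nitrogen, whereas here the whole (5-(tert-butyl)-1,2-oxazol-3-yl)amino group leaves and a smaller, non-aromatic pyrrolidin-1-yl enters. No shown step exchanges this group so fully, so the expectation rests on the weak sensitivity seen so far: a step of about a 1.2-fold higher number from compound 1 to compound 4 (0.07 log units; within the scatter) is expected, not clearly beyond the scatter, with some chance that only a limit is reported. For compound 4 the expected value is 40000 nM, between 15000 nM and 100000 nM.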

Compound 4, half-maximal inhibitory concentration: > 50000 nM
Compound 4 ended at the assay's limit (the forecaster's own chance of this, stated with the estimate: 35%); at least 1.2-fold (0.09 log units) between middle value and limit.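

Pyrrolidin-1-yl in place of (5-(tert-butyl)-1,2-oxazol-3-yl)amino on a carbonyl carbon replaces the whole group, rather than swapping one aromatic ring for another, and in this assay compound 4 gives > 50000 nM, which is a limit and not a number. The step is an at least 1.4-fold higher number from compound 1 to compound 4 (0.17 log units; that floor lies within the scatter), so this full exchange has no measured size, and its floor does not establish a loss of activity. Compound 1 and compound 3 keep an aromatic ring on the amide nitrogen and give plain numbers, whereas compound 4 has no such ring and gives none, but compound 2 goes against this simple reading by keeping the ring and still ending at a limit, so a ring alone does not secure a plain number: the limit of > 50000 nM in this assay, at which 2 of the 4 values shown sit.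

Pyrrolidin-1-yl removes the aromatic ring and the amide hydrogen at once, and the compounds shown do not separate these two changes. A cyclopentylamino group on the same carbonyl carbon would keep the amide hydrogen without an aromatic ring, while an N-methylanilino group would keep an aromatic ring without that hydrogen.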